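A carbonyl enters on an amine nitrogen

A few compounds are considered here, and "the series" means these few. Any claim that something is new, unique, unknown or untested is made for them only; others in the source may bear on it.

In a functional assay on OVCAR-3 cells (Homo sapiens) for antiproliferative activity, read by MTT assay, with a stated time of 24 h (on this read-out lower numbers stand for stronger inhibition and higher numbers for weaker inhibition), compound 1 `O=C(NNc1ccccc1Cl)c1ccc(NS(=O)(=O)c2cnc(O)nc2O)cc1` gives 7230 nM and compound 3 `O=C(NNc1cccc(Cl)c1)c1cccc(NS(=O)(=O)c2cnc(O)nc2O)c1` gives 8040 nM, two values within the scatter of each other. Compound 2 `O=C(NNc1ccccc1F)c1ccc(NS(=O)(=O)c2cnc(O)nc2O)cc1` reports only a limit, > 20000 nM. Compound 4 `O=C(NNC(=O)c1cccc(NS(=O)(=O)c2cnc(O)nc2O)c1)c1cccc(Cl)c1` differs from compound 3 by (3-chlorophenyl)carbonyl in place of 3-chlorophenyl on an amine nitrogen, with (3-chlorophenyl)carbonyl in place of 3-chlorophenyl on an amine nitrogen. For the measured compounds named here, the only measured step, an at least 2.7-fold higher number from compound 1 to compound 2 (0.44 log units; beyond the scatter), is fluoro in place of chloro on an aromatic carbon, a different change, so it offers only a loose guide to how far one change can move the number in this assay. A small move to a higher number, not clearly beyond the scatter, is expected. The expected step is a 1.6-fold higher number from compound 3 to compound 4 (0.21 log units; within the scatter). Compound 4 is estimated at 13000 nM, with an expected range of 5000 nM to 25000 nM.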

Compound 4, half-maximal inhibitory concentration: 13500 nM
The estimate for compound 4 lay 1.0-fold (0.02 log units) below the measured number; measured number inside the range.
By their numbers in this assay, from the lowest: compounds 1, 3 and 4 (each within the scatter of the next). At a limit, above all of these: compound 2.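

Read in this assay, the first change shown on this amine nitrogen rather than on an aromatic carbon gives a 1.7-fold higher number from compound 3 to compound 4 (0.23 log units; within the scatter), so adding the carbonyl to the 3-chlorophenyl group on this nitrogen moves the number by no more than the scatter. No evidence shown bears on the reason for this small step. From the compounds shown here alone, whether an acetyl group, a methyl group or a sulfonyl group on this nitrogen would behave alike remains open, as does whether the same carbonyl would give a comparable step on the core of compound 1.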